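The compounds below may be only part of what the source reports. "The series", "measured", "known", "first", "only" and "open" are said of these compounds alone.

Three compounds have been measured in an assay on cells for antagonist activity at transient receptor potential cation channel subfamily V member 1 (Homo sapiens), read by FLIPR and calcium flux, with a stated time of 6 min; on this read-out higher numbers stand for weaker inhibition and lower numbers for stronger inhibition:
compound 1 `CCCCN(C)c1cc(C(C)(C)C)ccc1CNC(=O)C(C)c1ccc(NS(C)(=O)=O)c(F)c1` gives 1 nM;
compound 2 `CCCOc1cc(C(C)(C)C)ccc1CNC(=O)C(C)c1ccc(NS(C)(=O)=O)c(F)c1` gives 4.4 nM;
compound 3 `CCCCOc1cc(C(C)(C)C)ccc1CNC(=O)C(C)c1ccc(NS(C)(=O)=O)c(F)c1` gives 1.4 nM.

Compound 3 stands second highest of the three numbers. Its nearest neighbour is compound 1, and the step of a 1.4-fold higher number from compound 1 to compound 3 (0.15 log units; within the scatter) lies within the scatter, so the two cannot be separated on these numbers. Compound 2 sits further off: the step of a 3.1-fold lower number from compound 2 to compound 3 (0.50 log units; beyond the scatter) is beyond the scatter.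

Compound 4 `CC(C)COc1cc(C(C)(C)C)ccc1CNC(=O)C(C)c1ccc(NS(C)(=O)=O)c(F)c1` is the unmeasured compound. It differs from compound 3 by isopropyl in place of propyl on a saturated chain carbon bound to an oxygen on an aromatic ring. Within the data shown here, none of the measured steps alters a chain by branching alone. The step of a 3.1-fold lower number from compound 2 to compound 3 (0.50 log units; beyond the scatter) extends the chain at its far end and brought a lower number; the step of a 4.4-fold higher number from compound 1 to compound 2 (0.64 log units; beyond the scatter) exchanges the linking atom together with the chain. Neither bears directly on moving a carbon from the end of the chain to a branch while the atoms stay the same. Among the measured compounds shown here, with no step of this kind measured, a change within the scatter is expected, with a slight lean toward a higher number: a 1.4-fold higher number from compound 3 to compound 4 (0.15 log units; within the scatter). Compound 4 is therefore expected at 2 nM, between 0.7 nM and 6 nM.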

Compound 4, inhibition constant: 2.1 nM
Estimate against measurement, compound 4: 1.1-fold (0.02 log units) below; the range from low to high includes it.
By their numbers in this assay, from the lowest: compounds 1, 3 and 4 (each within the scatter of the next, the first and the last beyond it); then compound 2.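

In this assay the change from butoxy to isobutoxy moves one carbon from the end of the chain to a branch and gives a 1.5-fold higher number from compound 3 to compound 4 (0.18 log units; within the scatter), so the two cannot be separated and this position accepts a branch of this kind on these numbers. The branched chain also stands apart from the shorter propoxy chain, with a 2.1-fold lower number from compound 2 to compound 4 (0.32 log units; beyond the scatter), so the lower number seen on extending the propoxy chain to butoxy is also found when the added carbon forms a branch. Exchanging butyl(methyl)amino for isobutoxy gives a 2.1-fold higher number from compound 1 to compound 4 (0.32 log units; beyond the scatter), a modest step beyond the scatter, whereas the unbranched butoxy compound could not be separated from the same amine, so the branch does show up in this one comparison.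

No measurement shown here explains why these chains give the numbers they do. From the compounds shown here alone, it remains open how this position responds to a branch on the carbon bound to the oxygen, as in isopropoxy, to a longer chain such as pentyloxy, or to a ring such as cyclopropylmethoxy.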